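The source may hold more compounds than are shown below. What is called first, only, known or untested is meant among the compounds shown, and "the series" means these compounds.

Measured so far:
compound 1 `CC(C)N1CCc2nc(C#Cc3ccccc3)ccc2C1=O` 1280 nM
compound 2 `Cc1ccccc1C#Cc1ccc2c(n1)CCN(C(C)C)C2=O` > 32000 nM

Compound 2 sits at a limit of an assay on HEK293 cells for displacement of a labelled ligand from metabotropic glutamate receptor 5 (Homo sapiens), with a stated time of 2 h; a lower number here means a stronger inhibitor, a higher number a weaker inhibitor: it reaches only (the limit of > 32000 nM in this assay, at which 1 of the 2 values shown sits), so no number is known for it. Among the compounds with values here, the one measured step bearing here is an at least 25-fold higher number from compound 1 to compound 2 (1.39 log units; beyond the scatter), a large loss. Compound 3 `Cc1cccc(C#Cc2ccc3c(n2)CCN(C(C)C)C3=O)c1` changes compound 2 by 3-methylphenyl in place of 2-methylphenyl on a triple-bonded carbon. With the methyl moved away from the position that caused that loss, a recovery toward the level of compound 1 is expected, so an at least 32-fold lower number from compound 2 to compound 3 (1.50 log units; beyond the scatter) is the estimated step in this assay. Compound 3 is therefore expected to give about 1000 nM, likely between 200 nM and 10000 nM.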

Compound 3, inhibition constant: 510 nM
Beside the measured number, compound 3's estimate is 2.0-fold (0.29 log units) above it; the measured number falls inside the stated range.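

In this assay, the same methyl gives opposite results depending on where it sits on the ring: 3-methylphenyl in place of 2-methylphenyl brings an at least 62-fold lower number from compound 2 to compound 3 (1.79 log units; beyond the scatter). The methyl of 3-methylphenyl is also more than tolerated, since adding it to the unsubstituted phenyl gives a 2.5-fold lower number from compound 1 to compound 3 (0.40 log units; beyond the scatter), a modest gain. The value of compound 2 is a limit, not a number, so the first step has no exact size: the limit of > 32000 nM in this assay, at which 1 of the 3 values shown sits.

Still open, going by these compounds, is whether an ethyl group, a methoxy group or a chlorine atom in place of that methyl would do as well in 3-methylphenyl's setting.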